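This account rests on a few compounds, and the source may have more. Where it says the series, first, only, none or still open, it means among the compounds named here.

In a functional assay on HeLa cells (Homo sapiens) for antiproliferative activity, read by MTT assay, with a stated time of 72 h (a higher number here means a weaker inhibitor, a lower number a stronger inhibitor), compound 1 `C/C=C/C(=O)Nc1cccc(Oc2nc(Nc3cccc(OC)c3)nc3c2CSCC3)c1` gives 13800 nM, and compound 2 `CC/C=C/C(=O)Nc1cccc(Oc2nc(Nc3cccc(OC)c3)nc3c2CSCC3)c1` gives 27200 nM. Going by the values given here, these two values lie within the scatter of each other, so compound 1 cannot be ranked against its only measured neighbour. Compound 3 `C/C=C/C(=O)Nc1cccc(Oc2nc(Nc3cccc(C#N)c3)nc3c2CSCC3)c1` keeps the core of compound 1 and has cyano in place of methoxy on an aromatic carbon, meta to a large group: cyano in place of methoxy on an aromatic carbon. Among the compounds with values here, the only measured step, a 2.0-fold higher number from compound 1 to compound 2 (0.29 log units; within the scatter), is methyl in place of hydrogen on a saturated chain carbon, so it does not touch this aromatic group. Within the data shown here, no measured pair shows the change from methoxy to cyano, and nothing points to a direction, so no step beyond the scatter is expected, though with wide uncertainty. The expected step is a 1.1-fold lower number from compound 1 to compound 3 (0.03 log units; within the scatter). The estimate for compound 3 is 13000 nM, with an expected range from 4000 nM to 40000 nM.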

Compound 3, half-maximal inhibitory concentration: 12800 nM
Estimate against measurement, compound 3: 1.0-fold (0.01 log units) above; the measured number falls inside the stated range.
By their numbers in this assay, from the lowest: compounds 3, 1 and 2 (each within the scatter of the next, the first and the last beyond it).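

In this assay, the exchange of methoxy for cyano on an aromatic carbon, meta to a large group, gives a 1.1-fold lower number from compound 1 to compound 3 (0.03 log units; within the scatter) and leaves the two numbers indistinguishable. Compounds 1 and 2 differ only at a saturated chain carbon, so they said nothing about this aromatic carbon; compound 3 shows that, for these two groups, replacing 3-methoxyphenyl with 3-cyanophenyl leaves the reading within the scatter. No measurement here explains why these two groups read alike.

Going by these compounds, whether this carbon would accept a very different group, such as an amine or a carboxylic acid, remains open. It is also unknown whether cyano would read the same way when combined with the chain of compound 2, since that pairing is not among the compounds shown.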